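This account rests on a few compounds, and the source may have more. Where it says the series, first, only, none or still open, it means among the compounds named here.

Series notes.

Measured so far in a functional assay on MCF7 cells (Homo sapiens) for antiproliferative activity, read by MTT assay, with a stated time of 48 h; on this read-out lower numbers stand for stronger inhibition and higher numbers for weaker inhibition:
- compound 1 `N#CC1=C(N)Oc2c(c3nc4ccccc4nc3c3ccccc23)C12C(=O)N(Cc1cnnn1-c1ccc(S(N)(=O)=O)cc1)c1ccccc12`: > 50000 nM
- compound 2 `Cc1ccc(C)c(-n2nncc2CN2C(=O)C3(C(C#N)=C(N)Oc4c3c3nc5ccccc5nc3c3ccccc43)c3ccccc32)c1`: > 50000 nM
- compound 3 `Cc1ccccc1-n1nncc1CN1C(=O)C2(C(C#N)=C(N)Oc3c(N)cc4nc5ccccc5nc4c32)c2ccccc21`: > 50000 nM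

Compound 1 gives only a limit of this assay, not a number. Compound 2 likewise gives only a limit. Compound 3, the starting point here, also stands only at a limit in this assay, so its true position is not known; it shares that limit with the other two, as the limit of > 50000 nM in this assay, at which 3 of the 3 values shown sit, shows.

Among the measured compounds shown here, the only step between measured compounds is a step that the two limits leave unreadable from compound 1 to compound 2, a change of the aryl group on the triazole nitrogen, and it stays unreadable in this assay since both ends are limits.

Compound 4 `N#CC1=C(N)Oc2c(N)cc3nc4ccccc4nc3c2C12C(=O)N(Cc1cnnn1-c1ccc(Cl)cc1)c1ccccc12` differs from compound 3 in the same place: 4-chlorophenyl in place of 2-methylphenyl on an aromatic nitrogen. For the measured compounds named here, the one measured step in this position, from compound 1 to compound 2, gives no readable size, so no direction and no size can be drawn from it; the expectation rests on all three measured values sitting at the limit.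

Compound 4 is therefore expected to give 50000 nM in this assay, with a range from 15000 nM to 150000 nM. The step from compound 3 to compound 4 is expected to be a number no higher from compound 3 to compound 4 (the limit leaves the size open), most likely again reported only as a limit.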

Compound 4, half-maximal inhibitory concentration: > 50000 nM
Compound 4: no number, only a limit (the forecaster's own chance of this, stated with the estimate: 85%); the middle value sits exactly at the limit.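

In this assay compound 3 and compound 4 both stand only at a limit, so no step can be read between them. The series still shares a single ceiling: the limit of > 50000 nM in this assay, at which 4 of the 4 values shown sit.

The compounds shown leave open how far each lies beyond that limit and whether any aryl group on the triazole nitrogen affects the read-out.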